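The source may hold more compounds than are shown below. What is called first, only, known or untested is meant among the compounds shown, and "the series" means these compounds.

Measured in a functional assay on DLD-1 cells (Homo sapiens) for antiproliferative activity, read by CellTiter-Glo, with a stated time of 72 h; a lower number here means a stronger inhibitor, a higher number a weaker inhibitor:
- compound 1 `CC1CCN(C2CCN(S(=O)(=O)c3cnc(Cl)s3)CC2)CC1`: 1800 nM
- compound 2 `CC1CCN(C2CCN(S(=O)(=O)c3cccc(Cl)c3)CC2)CC1`: > 5000 nM (a limit)
- compound 3 `CC1CCN(C2CCN(S(=O)(=O)c3cncc(Br)c3)CC2)CC1`: > 5000 nM (a limit)

Compound 3 has no numerical value, only the limit > 5000 nM. That places it at the limit of > 5000 nM in this assay, at which 2 of the 3 values shown sit.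

Compound 4 `CC1CCN(C2CCN(S(=O)(=O)c3ccc(Cl)cc3Cl)CC2)CC1` carries 2,4-dichlorophenyl in place of 5-bromopyridin-3-yl on a sulfonyl sulfur.

Two measured steps leave 2-chloro-1,3-thiazol-5-yl, and both are beyond the scatter: an at least 2.7-fold higher number from compound 1 to compound 2 (0.44 log units; beyond the scatter) and an at least 2.7-fold higher number from compound 1 to compound 3 (0.44 log units; beyond the scatter). Neither tests the change to 2,4-dichlorophenyl directly. The step between the two compounds at the limit is a step that the two limits leave unreadable from compound 2 to compound 3. Compound 4 also lacks 2-chloro-1,3-thiazol-5-yl, and the closest comparison is compound 2 with 3-chlorophenyl, at > 5000 nM. On this evidence, no step beyond the scatter is expected in this assay, and a further result at the limit would be unsurprising. The expected change is a number no higher from compound 3 to compound 4 (the limit leaves the size open). For compound 4 the estimated value is 5000 nM, with an expected range from 1800 nM to 12000 nM.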

Compound 4, half-maximal inhibitory concentration: 1 nM
Estimate against measurement, compound 4: 5000-fold (3.70 log units) above; measured number outside the range, below it.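

The change to 2,4-dichlorophenyl on the sulfonyl sulfur shows that this position can carry very high activity in this assay, with an at least 5000-fold lower number from compound 3 to compound 4 (3.69 log units; beyond the scatter) and, against a group that also holds chlorine on a ring of carbon only, an at least 5000-fold lower number from compound 2 to compound 4 (3.69 log units; beyond the scatter). Among these compounds, it also goes far past the one earlier compound with a numerical value, with a 1800-fold lower number from compound 1 to compound 4 (3.26 log units; beyond the scatter), so a ring of carbon only with chlorine is not enough by itself, as compound 2 goes against any such pattern. The first two steps are bounds and not sizes, because compound 2 and compound 3 give only limits: the limit of > 5000 nM in this assay, at which 2 of the 4 values shown sit.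

What the four compounds leave open is whether a methyl or methoxy group could stand in place of either chlorine and keep this activity. They also cannot say why this one change has so large a step, and the rest of the shared core stays the same throughout.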